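From a Cyclohexylmethyl Amide to an Octyl Amide

The source may hold more compounds than are shown below. What is called first, only, known or untested is meant among the compounds shown, and "the series" means these compounds.

In a functional assay for inhibition, with Rattus norvegicus as the target, at pH 7.35 (a lower number here means a stronger inhibitor, a higher number a weaker inhibitor), compound 1 `CCCCOC(=O)C(=O)C(CC)NC(=O)C(CC(C)C)NC(=O)OCc1ccccc1` gives 28000 nM, while compound 2 `CCC(NC(=O)C(CC(C)C)NC(=O)OCc1ccccc1)C(=O)C(=O)NCC1CCCCC1` gives 66000 nM. Compound 2 therefore has the higher of the two numbers and is the weaker inhibitor of the pair. Compound 3 `CCCCCCCCNC(=O)C(=O)C(CC)NC(=O)C(CC(C)C)NC(=O)OCc1ccccc1` differs from it by heptyl in place of cyclohexyl on a saturated chain carbon bound to an amide-type nitrogen, with heptyl in place of cyclohexyl on a saturated chain carbon bound to an amide-type nitrogen. For the measured compounds named here, only one measured step bears on this change, and only indirectly: the modest 2.4-fold higher number from compound 1 to compound 2 (0.37 log units; beyond the scatter), with (cyclohexylmethyl)amino in place of butoxy on a carbonyl carbon. Going by the values given here, no measured step replaces a ring with a chain, so the direction remains uncertain. A change of similar or smaller size is expected, most likely none beyond the scatter. The expected step is a 1.2-fold lower number from compound 2 to compound 3 (0.08 log units; within the scatter). For compound 3 the estimate is 55000 nM, with an expected range of 22000 nM to 130000 nM.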

Compound 3, half-maximal inhibitory concentration: 200000 nM
Estimate against measurement, compound 3: 3.6-fold (0.56 log units) below, and the stated range ends below it.
By their numbers in this assay, from the lowest: compound 1; then compound 2; then compound 3.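

In this assay, the ring-to-chain change at this position is not neutral: heptyl in place of cyclohexyl on a saturated chain carbon bound to an amide-type nitrogen gives a 3.0-fold higher number from compound 2 to compound 3 (0.48 log units; beyond the scatter). For the compounds shown here, this is the first measured step in which a ring gives way to an open chain here, and the chain compound is the weaker inhibitor. The second amide also stands further from the butoxy compound than the first did, with octylamino in place of butoxy on a carbonyl carbon giving a 7.1-fold higher number from compound 1 to compound 3 (0.85 log units; beyond the scatter), and no measurement shown explains either step.

Since the ring is lost and a carbon gained in one change, these compounds cannot separate the two. Going by these compounds, it remains open how a shorter chain such as butylamino or a benzylamino group would compare on the same carbonyl carbon.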